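A few compounds are considered here, and "the series" means these few. Any claim that something is new, unique, unknown or untested is made for them only; others in the source may bear on it.

Compound 1 `COc1cc2c(Oc3ccc(NC(=O)c4nn(-c5ccc(Cl)cc5)c(=O)cc4C)cc3F)ccnc2cc1OCCCN1CCCC1` gives 150 nM in a functional assay on MKN-45 cells (Homo sapiens) for inhibition, read by MTT assay, with a stated time of 72 h; a higher number here means a weaker inhibitor, a lower number a stronger inhibitor.
Compound 2 `COc1cc2c(Oc3ccc(NC(=O)c4nn(-c5ccc(Cl)cc5)c(=O)cc4C)cc3F)ccnc2cc1OCCCN1CCCCC1` gives 230 nM in this assay.

Compound 2 and compound 1 are separated only by a 1.5-fold higher number from compound 1 to compound 2 (0.19 log units; within the scatter), a step within the scatter, so the two sit together on the numbers shown. Compound 3 `COc1cc2c(Oc3ccc(NC(=O)c4nn(-c5ccc(Cl)cc5)c(=O)cc4C)cc3F)ccnc2cc1OCCCN1CCN(C)CC1` differs from compound 2 at the chain end alone: 4-methylpiperazin-1-yl in place of piperidin-1-yl on a saturated chain carbon, three bonds along the chain from an oxygen on an aromatic ring. Within the data shown here, the single measured step at that position, a 1.5-fold higher number from compound 1 to compound 2 (0.19 log units; within the scatter), stayed within the scatter; on that basis the move to compound 3 is expected to be a 1.1-fold higher number from compound 2 to compound 3 (0.04 log units; within the scatter), no step beyond the scatter. Compound 3 is therefore estimated at 250 nM, with a range of 120 nM to 550 nM.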

Compound 3, half-maximal inhibitory concentration: 40 nM
Compound 3: middle estimate off by 6.3-fold (0.80 log units), on the high side, and the stated range ends above it.
By their numbers in this assay, from the lowest: compound 3; then compounds 1 and 2 (each within the scatter of the next).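

Placing 4-methylpiperazin-1-yl at the chain end gives a 5.8-fold lower number from compound 2 to compound 3 (0.76 log units; beyond the scatter), and measured against the pyrrolidin-1-yl end it gives a 3.8-fold lower number from compound 1 to compound 3 (0.57 log units; beyond the scatter). Both steps lie beyond the scatter, so this position, which looked flat from compound 1 and compound 2 alone, does respond to the group at the chain end in this assay. Nothing available here explains the change.

From the compounds shown here alone, it stays open whether the gain follows the second ring nitrogen or its methyl, which an unmethylated piperazin-1-yl or a morpholin-4-yl end would help separate. Also open, going by these compounds, is whether it holds on a shorter or longer chain than 3-(4-methylpiperazin-1-yl)propyl.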